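A few compounds are considered here, and "the series" means these few. Any claim that something is new, unique, unknown or untested is made for them only; others in the source may bear on it.

Measured so far in an ADME assay on Li23 cells (Homo sapiens) for cytotoxicity, read by WST assay; a lower number here means that less compound is tolerated, a higher number that more compound is tolerated:
- compound 1 `Cc1ccc(C(=O)N(C)c2ccc(C(O)(C(F)(F)F)C(F)(F)F)cc2)cc1` gives 26000 nM
- compound 2 `CCCC(=O)N(C)c1ccc(C(O)(C(F)(F)F)C(F)(F)F)cc1` reaches only the assay limit, > 100000 nM, which is a limit and not a number
- compound 3 `CN(C(=O)C1CCCCC1)c1ccc(C(O)(C(F)(F)F)C(F)(F)F)cc1` gives 20000 nM

Compound 3 holds the lowest of the two real numbers in this assay, but the step of a 1.3-fold lower number from compound 1 to compound 3 (0.11 log units; within the scatter) lies within the scatter, so compound 1 and compound 3 cannot be ordered. The third value is a limit: the limit of > 100000 nM in this assay, at which 1 of the 3 values shown sits.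

The next step goes to compound 4 `CN(C(=O)c1ccsc1)c1ccc(C(O)(C(F)(F)F)C(F)(F)F)cc1`: thiophen-3-yl in place of cyclohexyl on a carbonyl carbon.

Within the data shown here, three measured steps bear on it, all swaps of the group on the carbonyl carbon beside the amide-type nitrogen. Swapping 4-methylphenyl for cyclohexyl, a 1.3-fold lower number from compound 1 to compound 3 (0.11 log units; within the scatter), changed nothing beyond the scatter. Propyl stands apart: an at least 3.8-fold higher number from compound 1 to compound 2 (0.58 log units; beyond the scatter) and an at least 5.0-fold lower number from compound 2 to compound 3 (0.69 log units; beyond the scatter) both run beyond the scatter, the propyl compound sitting at the limit. Thiophen-3-yl is a flat aromatic ring, closer in kind to 4-methylphenyl than to propyl, and the aromatic-to-cycloalkyl swap already moved nothing.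

The step of a 1.3-fold higher number from compound 3 to compound 4 (0.10 log units; within the scatter) is therefore expected to stay within the scatter, with no clear direction. For compound 4 the estimate in this assay is 25000 nM, with a range from 10000 nM to 70000 nM.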

Compound 4, half-maximal cytotoxic concentration: 44000 nM
The estimate for compound 4 lay 1.8-fold (0.25 log units) below the measured number, within the range that was stated.
By their numbers in this assay, from the lowest: compounds 3, 1 and 4 (each within the scatter of the next, the first and the last beyond it). At a limit, above all of these: compound 2.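

In this assay, among these compounds, thiophen-3-yl gives the first swap between ring groups on this carbonyl carbon that clears the scatter: a 2.2-fold higher number from compound 3 to compound 4 (0.34 log units; beyond the scatter). The companion step, a 1.7-fold higher number from compound 1 to compound 4 (0.23 log units; within the scatter), does not clear it, so compound 1 cannot be separated from either compound 3 or compound 4, although those two are separated from each other, and only by a modest step; the ring groups therefore no longer read as a single level, but they do not form a full order. The open-chain propyl group still stands apart from the rings, with an at least 2.2-fold lower number from compound 2 to compound 4 (0.35 log units; beyond the scatter), a step that gives a bound and not a size, as the value of compound 2 is a limit: the limit of > 100000 nM in this assay, at which 1 of the 4 values shown sits.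

The compounds shown do not tell whether the aromatic ring or the sulfur atom goes with the step from cyclohexyl to thiophen-3-yl, a question on which an unsubstituted phenyl or a furanyl group on the same carbonyl carbon would bear. Also open, going by these compounds, is whether ethyl or a longer chain in that place would match propyl and also reach the limit, or would give a real number.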